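Losing the Side Chain on the Aromatic Nitrogen

The source may report more compounds than this note shows. Statements on the series, on what has been measured and on what is new or still open speak of the compounds shown alone.

Compound 1 `CN(C)CCCCCn1c2c(c3ccccc31)C(=O)c1c[n+]([O-])c3ccccc3c1C2=O`: 210 nM
Compound 2 `CC1(C)O[C@@H](CO)[C@H](Cn2cc(Cn3c4c(c5ccccc53)C(=O)c3c[n+]([O-])c5ccccc5c3C4=O)nn2)O1`: 370 nM

In a functional assay on A549 cells (Homo sapiens) for cytotoxicity, read by MTT assay, with a stated time of 72 h (on this read-out lower numbers stand for stronger inhibition and higher numbers for weaker inhibition), compound 1 gives 210 nM, and compound 2 gives 370 nM. Compound 1 holds the lowest of the two numbers, yet its gap to compound 2 lies within the scatter, so neither can be called the more potent. Compound 3 `O=C1c2c[n+]([O-])c3ccccc3c2C(=O)c2[nH]c3ccccc3c21` has not yet been measured. It differs from compound 1 in one place: hydrogen in place of 5-(dimethylamino)pentyl on an aromatic nitrogen. Among the compounds with values here, no step between measured compounds shows what such a change does. Compound 3 is expected to give a higher number in this assay, a step beyond the scatter, a 3.8-fold higher number from compound 1 to compound 3 (0.58 log units; beyond the scatter). For compound 3 the estimated value is 800 nM, with a range from 250 nM to 3000 nM.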

Compound 3, half-maximal inhibitory concentration: 320 nM
Compound 3: middle estimate off by 2.5-fold (0.40 log units), on the high side; measured number inside the range.
By their numbers in this assay, from the lowest: compounds 1, 3 and 2 (each within the scatter of the next).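

In this assay, hydrogen in place of 5-(dimethylamino)pentyl on the aromatic nitrogen gives a 1.5-fold higher number from compound 1 to compound 3 (0.18 log units; within the scatter). At this position, the full chain can therefore be exchanged for hydrogen without a step beyond the scatter, so this one comparison gives no sign that the chain is needed for the cytotoxicity read-out. No measurement shown bears on why this is so. On these data alone, it remains open whether a methyl group on this nitrogen would also stay within the scatter of compound 1. The same question applies to a pentyl chain ending in a carboxylic acid.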